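A few compounds are considered here, and "the series" means these few. Any claim that something is new, unique, unknown or untested is made for them only; others in the source may bear on it.

Measured compounds in an assay on DDT1 cells (Cricetulus griseus) for binding affinity to adenosine receptor A1 (Homo sapiens), read by radioligand binding; a lower number here means a stronger inhibitor, a higher number a weaker inhibitor:
compound 1 `CC/N=C(\S)OC[C@H]1OC(n2cnc3c(NC4CCOC4)ncnc32)[C@H](O)[C@@H]1O` gives 33 nM
compound 2 `O=C(NC1CCCCC1)OC[C@H]1OC(n2cnc3c(NC4CCOC4)ncnc32)[C@H](O)[C@@H]1O` gives 584 nM
compound 3 `O=C(NCc1ccccc1)OC[C@H]1OC(n2cnc3c(NC4CCOC4)ncnc32)[C@H](O)[C@@H]1O` gives 1830 nM

Compound 3 stands at the weak end of this set: the step of a 3.1-fold higher number from compound 2 to compound 3 (0.50 log units; beyond the scatter) is modest, while a 55-fold higher number from compound 1 to compound 3 (1.74 log units; beyond the scatter) is large.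

Compound 4 `O[C@@H]1[C@@H](CO/C(S)=N/Cc2ccccc2)OC(n2cnc3c(NC4CCOC4)ncnc32)[C@@H]1O` differs from compound 3 by a group of 10 heavy atoms (8 carbon, 1 nitrogen, 1 sulfur; one six-membered aromatic ring of carbon only) in place of a group of 10 heavy atoms (8 carbon, 1 nitrogen, 1 oxygen; one six-membered aromatic ring of carbon only), on an oxygen on a saturated carbon. Among the measured compounds shown here, no measured pair isolates this carbamate-to-thiocarbamate exchange with the nitrogen substituent held constant. The closest bearings are the steps from compound 1, which carries the sulfur-containing group: an 18-fold higher number from compound 1 to compound 2 (1.25 log units; beyond the scatter) and a 55-fold higher number from compound 1 to compound 3 (1.74 log units; beyond the scatter), both large, but each combines the heteroatom exchange with a change of the group on the nitrogen. The step of a 3.1-fold higher number from compound 2 to compound 3 (0.50 log units; beyond the scatter), which changes only the group on the nitrogen, is modest. The step of a 55-fold higher number from compound 1 to compound 3 (1.74 log units; beyond the scatter), which changes both the heteroatom and the group on the nitrogen, is large. The second of these steps is well beyond the first. Compound 4 is therefore expected to move toward compound 1, with a step of a 6.1-fold lower number from compound 3 to compound 4 (0.79 log units; beyond the scatter) in the direction of a lower number, beyond the scatter but short of the full gap to compound 1. For compound 4 in this assay the estimate is 300 nM, with a range from 80 nM to 1200 nM.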

Compound 4, inhibition constant: 12 nM
The estimate for compound 4 lay 25-fold (1.40 log units) above the measured number; the measured number lies below the stated range.
By their numbers in this assay, from the lowest: compound 4; then compound 1; then compound 2; then compound 3.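

In this assay, among the compounds shown here, with the benzyl group held constant on the nitrogen, the exchange of the carbamate oxygen for the sulfur-bearing group at this position gives a 150-fold lower number from compound 3 to compound 4 (2.18 log units; beyond the scatter), the first step to isolate that change, and it is large. The sulfur-bearing group also carries benzyl without loss: a 2.8-fold lower number from compound 1 to compound 4 (0.44 log units; beyond the scatter) is a modest move toward a lower number as the nitrogen substituent grows, and a 49-fold lower number from compound 2 to compound 4 (1.69 log units; beyond the scatter) is large, though that step changes the nitrogen substituent as well, so compound 4 now has the lowest number of the four. No measurement shown here accounts for the size of the exchange.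

As far as these compounds go, the same exchange is seen with only one nitrogen substituent, so whether it holds for the cyclohexyl pair, or for the ethyl carbamate matched to compound 1, remains open. A longer chain such as phenethyl on the nitrogen, or a substituted benzyl such as 4-chlorobenzyl, would show how far the trend toward lower numbers with the sulfur-bearing group extends.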